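Aryl change from compound 3 to compound 4: cytotoxicity

The compounds below may be only part of what the source reports. "The series", "measured", "known", "first", "only" and "open" are said of these compounds alone.

The three measured compounds share one core. Compound 3 `O=C(COc1cccc2ccccc12)N/N=C/c1ccccc1O` gives 3.57 ug/mL in an ADME assay on HEL cells (Homo sapiens) for cytotoxicity (on this read-out lower numbers stand for higher toxicity in this test and higher numbers for lower toxicity in this test), the lowest number of the three. Compound 1 `C/C(=N\NC(=O)COc1cccc2ccccc12)c1cccc([N+](=O)[O-])c1` gives 10.5 ug/mL in this assay, and compound 2 `O=C(COc1cccc2ccccc12)N/N=C/c1cccc(O)c1` gives 62.7 ug/mL. Among the measured compounds shown here, the only single-point step measured, an 18-fold lower number from compound 2 to compound 3 (1.24 log units; beyond the scatter), is large.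

Compound 4 `O=C(COc1cccc2ccccc12)N/N=C/c1cccc(Br)c1` differs from compound 3 by 3-bromophenyl in place of 2-hydroxyphenyl on a carbon with a double bond to nitrogen. For the measured compounds named here, no measured step covers this change directly: the step from compound 2 to compound 3 shifts a hydroxyl within the phenyl, whereas here the hydroxyl leaves altogether and bromine enters. Still, the step of an 18-fold lower number from compound 2 to compound 3 (1.24 log units; beyond the scatter) shows that the 2-hydroxyphenyl gives a markedly lower number than the 3-hydroxyphenyl, so leaving the 2-hydroxyphenyl may raise the number. Compound 1, which is not a single-point neighbour but carries a 3-nitrophenyl, gives 10.5 ug/mL, between the two. A moderate rise is therefore expected, a 5.0-fold higher number from compound 3 to compound 4 (0.70 log units; beyond the scatter). For compound 4 the estimate in this assay is 18 ug/mL, with a range of 6 ug/mL to 55 ug/mL.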

Compound 4, half-maximal cytotoxic concentration: 48.6 ug/mL
Compound 4: the middle estimate sits 2.7-fold (0.43 log units) below what was measured; low and high end bracket the measured number.
By their numbers in this assay, from the lowest: compound 3; then compound 1; then compounds 4 and 2 (each within the scatter of the next).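

In this assay, the low number stays with the 2-hydroxyphenyl: the step of an 18-fold lower number from compound 2 to compound 3 (1.24 log units; beyond the scatter) now has a counterpart in the step of a 14-fold higher number from compound 3 to compound 4 (1.13 log units; beyond the scatter). The step of a 1.3-fold lower number from compound 2 to compound 4 (0.11 log units; within the scatter) shows that bromo in place of hydroxy on an aromatic carbon leaves the number within the scatter, so among these compounds the low number goes with the 2-hydroxyphenyl and not with a hydroxy group as such. Nothing available explains why the 2-hydroxyphenyl stands apart in this way.

The compounds shown leave open whether the low number needs the hydroxy group of the 2-hydroxyphenyl, or whether an amine or a methoxy group in its place would give the same result. They also give no reference for a plain phenyl on the carbon with a double bond to nitrogen.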